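Swapping one sulfonamide group: compound 1 to compound 3

The source may hold more compounds than are shown below. What is called first, only, known or untested is meant among the compounds shown, and "the series" means these compounds.

Compound 1 `CC(C)CN(c1cc2ccccc2s1)S(=O)(=O)c1ccc2c(c1)C(=O)CC(C1CCOCC1)O2` measured 4.01
Compound 2 `CCc1ccc(N(CC(C)C)S(=O)(=O)c2ccc3c(c2)C(=O)C[C@@H](C2CCOCC2)O3)cc1` measured 4.2

Both numbers come from a physicochemical assay for lipophilicity, at pH 7.4 (a lower number here means a more polar compound, a higher number a more lipophilic compound), and they are the only two available so far. Compound 1 stands within the usual scatter of compound 2, meaning the spread seen when such a measurement is repeated, so the two values cannot be told apart.

Compound 3 `CC(C)CN(c1ccc(F)cc1)S(=O)(=O)c1ccc2c(c1)C(=O)CC(C1CCOCC1)O2` has not yet been measured. It keeps the core of compound 1 but carries 4-fluorophenyl in place of 1-benzothiophen-2-yl on a sulfonamide nitrogen. Among the compounds with values here, no pair of measured compounds differs in one place, so no measured step can guide this change, and the expectation rests on the structural change alone. Starting from compound 1 at 4.01 on this scale, a moderate move to a lower number in this assay is expected, though a result within the scatter remains possible. The expected change is a number 0.41 log units lower from compound 1 to compound 3 (beyond the scatter) on this scale. For compound 3 the estimate is 3.6 with an expected range from 3.2 to 3.95 as its upper end.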

Compound 3, distribution coefficient: 3.48
The estimate for compound 3 lay 0.12 log units above the measured number, within the range that was stated.
By their numbers in this assay, from the lowest: compound 3; then compounds 1 and 2 (each within the scatter of the next).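

Within the data shown here, this is the first comparison between two compounds that differ in only one place. On a sulfonamide nitrogen whose other neighbours are a saturated chain carbon and the sulfonyl sulfur, putting 4-fluorophenyl in place of 1-benzothiophen-2-yl gives, in this assay, a number 0.53 log units lower from compound 1 to compound 3 (beyond the scatter), so the group at this position can shift the read-out by more than repeat measurements would. The swap changes several things at once, removing the five-membered aromatic ring with its sulfur and bringing in a fluorine, and nothing measured here shows which of these matters or why the number falls.

Going by these compounds, it remains open whether a plain phenyl, a pyridyl ring or a phenyl carrying an amine on this nitrogen would give a number close to that of compound 3 or to that of compound 1. On these data alone, the saturated chain on the same nitrogen is the same in both compounds, so the effect of a longer chain or a cyclopropylmethyl group there also remains open.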